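The source may report more compounds than this note shows. Statements on the series, on what has been measured and on what is new or still open speak of the compounds shown alone.

Measured so far in a functional assay on SK-OV-3 cells (Homo sapiens) for antiproliferative activity, read by MTT assay, with a stated time of 72 h (on this read-out higher numbers stand for weaker inhibition and lower numbers for stronger inhibition), as follows
compound 1 `CC(=O)c1ccc(-c2cccc(NC(=O)CCc3ccc4c(c3)COB4O)c2)cc1` gives 79000 nM
compound 2 `O=C(CCc1cccc2c1C(O)OC2)Nc1ccccc1` gives 78000 nM
compound 3 `COc1cccc(-c2cccc(NC(=O)CCc3cccc4c3C(O)OC4)c2)c1` gives 61000 nM

Compound 4 `CC(=O)c1ccc(-c2cccc(NC(=O)CCc3cccc4c3C(O)OC4)c2)cc1` has not yet been measured. The three values lie within the scatter of one another, so compound 3 stands level with compound 1 and compound 2, and no order can be read among them.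

The change to follow is 4-acetylphenyl in place of 3-methoxyphenyl on an aromatic carbon with 4-acetylphenyl in place of 3-methoxyphenyl on an aromatic carbon, meta to a large group. Within the data shown here, the one measured step bearing on it is a 1.3-fold lower number from compound 2 to compound 3 (0.11 log units; within the scatter) on placing 3-methoxyphenyl in place of hydrogen, so adding that whole group stayed within the scatter. Compound 1 carries the 4-acetylphenyl group on a different core and gives 79000 nM in the same series of results.

No step beyond the scatter is therefore expected in this assay for this exchange. The expected change is a 1.1-fold higher number from compound 3 to compound 4 (0.03 log units; within the scatter) and no more than that. For compound 4 the estimated value is 65000 nM with an expected range of 32000 nM to 110000 nM in these cells.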

Compound 4, half-maximal inhibitory concentration: 41000 nM
Estimate against measurement, compound 4: 1.6-fold (0.20 log units) above, within the range that was stated.
By their numbers in this assay, from the lowest: compounds 4, 3, 2 and 1 (each within the scatter of the next).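

In this assay, 4-acetylphenyl in place of 3-methoxyphenyl on this aromatic carbon gives (a 1.5-fold lower number from compound 3 to compound 4 (0.17 log units; within the scatter)), so the exchange of one aryl group for the other brings no step beyond the scatter. Set against hydrogen on the same carbon, 4-acetylphenyl gives (a 1.9-fold lower number from compound 2 to compound 4 (0.28 log units; within the scatter)), and with 4-acetylphenyl held constant, the exchange of core gives (a 1.9-fold lower number from compound 1 to compound 4 (0.28 log units; within the scatter)), so neither the added group nor the core separates these compounds on this read-out. No evidence is at hand to explain why these values stay level.

Going by these compounds, whether an amine or a carboxylic acid on the added phenyl ring, or a longer chain in place of the present one, would give a step beyond the scatter remains open. Also open, on these data alone, is whether the level values hold on any other read-out.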